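Amide variation on a benzimidazolyl-thiazole cytotoxic series

The source may hold more compounds than are shown below. What is called first, only, known or untested is meant among the compounds shown, and "the series" means these compounds.

Compound 1, `CCOC(=O)c1sc(-c2nc3ccccc3n2Cc2ccccc2)nc1C`: 2780 nM
Compound 2, `Cc1nc(-c2nc3ccccc3n2Cc2ccccc2)sc1C(=O)Nc1ccccc1`: 3700 nM

Of the compounds shown here, two have been tested in a functional assay on SMMC-7721 cells (Homo sapiens) for cytotoxicity, read by MTT assay, with a stated time of 24 h; a lower number here means a stronger inhibitor, a higher number a weaker inhibitor. Compound 2 gives 3700 nM, and compound 1 gives 2780 nM, so the two stand within the scatter of each other and no order between them can be claimed. Among the compounds with values here, the one measured step, a 1.3-fold higher number from compound 1 to compound 2 (0.12 log units; within the scatter), shows that exchanging the group on the carbonyl carbon left the number essentially where it was.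

Compound 3, `Cc1nc(-c2nc3ccccc3n2Cc2ccccc2)sc1C(=O)N1CCCCC1`, has not yet been measured. It differs from compound 2 by piperidin-1-yl in place of anilino on a carbonyl carbon. Within the data shown here, the only step that bears on this change is the one from compound 1 to compound 2, and that lay within the scatter, so nothing in the data points toward a shift in either direction. Compound 3 is therefore expected to give a number near that of compound 2, with an estimated step of a 1.1-fold lower number from compound 2 to compound 3 (0.02 log units; within the scatter). The estimate for compound 3 is 3500 nM, within a range of 1200 nM to 10000 nM.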

Compound 3, half-maximal inhibitory concentration: > 20000 nM
Compound 3: no number, only a limit (the forecaster's own chance of this, stated with the estimate: 5%); middle value at least 5.7-fold (0.75 log units) away from the limit.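

In this assay compound 3 gives no number, only a limit: the limit of > 20000 nM in this assay, at which 1 of the 3 values shown sits. Exchanging ethoxy for anilino had left the number in place, but piperidin-1-yl on the same carbonyl carbon brings an at least 5.4-fold higher number from compound 2 to compound 3 (0.73 log units; beyond the scatter) and, set against ethoxy, an at least 7.1-fold higher number from compound 1 to compound 3 (0.85 log units; beyond the scatter) as well. This position therefore responds to the group it carries, and the tolerance seen between the first two groups does not extend to piperidin-1-yl.

The compounds shown leave open whether the loss follows the missing amide hydrogen or the exchange of the aromatic ring for a non-aromatic one, since both change together in this step. A cyclohexylamino group, which would keep the amide hydrogen on a non-aromatic ring, or a morpholin-4-yl group would bear on that question.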